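Hydrazone aryl swap: indole replaces dimethoxyphenyl

The compounds below may be only part of what the source reports. "The series", "measured", "known", "first", "only" and "open" are said of these compounds alone.

Measured so far:
compound 1 `COc1cc2c(Oc3ccc(NC(=O)N/N=C/c4ccc(F)cc4Cl)cc3F)ccnc2cc1OCCCN1CCCCC1` 130 nM
compound 2 `COc1cc2c(Oc3ccc(NC(=O)N/N=C/c4ccc(OC(F)(F)F)cc4)cc3F)ccnc2cc1OCCCN1CCCCC1` 590 nM
compound 3 `COc1ccc(/C=N/NC(=O)Nc2ccc(Oc3ccnc4cc(OCCCN5CCCCC5)c(OC)cc34)c(F)c2)c(OC)c1` 1400 nM

In a functional assay on A549 cells (Homo sapiens) for cytotoxicity, read by MTT assay, with a stated time of 72 h (a lower number here means a stronger inhibitor, a higher number a weaker inhibitor), compound 3 gives the highest of the three numbers, with compound 2 nearest and compound 1 furthest. Compound 4 `COc1cc2c(Oc3ccc(NC(=O)N/N=C/c4cc5ccccc5[nH]4)cc3F)ccnc2cc1OCCCN1CCCCC1` differs from compound 3 by 1H-indol-2-yl in place of 2,4-dimethoxyphenyl on a carbon with a double bond to nitrogen. Among the measured compounds shown here, no measured step involves an indolyl group; the bearing steps are the other aryl exchanges at the same carbon, a 4.5-fold higher number from compound 1 to compound 2 (0.66 log units; beyond the scatter), an 11-fold higher number from compound 1 to compound 3 (1.03 log units; beyond the scatter) and a 2.4-fold higher number from compound 2 to compound 3 (0.38 log units; beyond the scatter), which show that this position tolerates changes of modest to large size in either direction. A step of similar size is therefore expected, most likely toward a lower number, since compound 3 already stands highest. Compound 4 is estimated at 600 nM, range 150 nM to 3000 nM, a step of a 2.3-fold lower number from compound 3 to compound 4 (0.37 log units; beyond the scatter).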

Compound 4, half-maximal inhibitory concentration: 780 nM
Beside the measured number, compound 4's estimate is 1.3-fold (0.11 log units) below it, and the stated range covers the measured number.
By their numbers in this assay, from the lowest: compound 1; then compounds 2, 4 and 3 (each within the scatter of the next, the first and the last beyond it).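

In this assay, among the compounds shown here, 1H-indol-2-yl, the only group here with a hydrogen-bond donor, stays within the scatter of 2,4-dimethoxyphenyl (a 1.8-fold lower number from compound 3 to compound 4 (0.25 log units; within the scatter)) and of 4-(trifluoromethoxy)phenyl (a 1.3-fold higher number from compound 2 to compound 4 (0.12 log units; within the scatter)). Only 2-chloro-4-fluorophenyl stands clear of it (a 6.0-fold higher number from compound 1 to compound 4 (0.78 log units; beyond the scatter)), so adding a five-membered aromatic ring and a donor at this carbon did not match compound 1. No measurement shown explains this result. Still open, on these data alone, is whether an aromatic ring carrying an amine or a carboxylic acid at this carbon would reach compound 1, and whether its chlorine or its fluorine matters more.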